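The source may hold more compounds than are shown below. What is called first, only, known or untested is meant among the compounds shown, and "the series" means these compounds.

Compound 3 `Nc1cc(C2CCCCC2)nc2ccc(NC(=O)/C=C/c3ccc(C(F)(F)F)cc3)cc12` gives 1.2 nM in an assay on isolated protein for displacement of a labelled ligand from melanin-concentrating hormone receptor 1 (Homo sapiens) (on this read-out lower numbers stand for stronger inhibition and higher numbers for weaker inhibition), the second highest of the three numbers; compound 1 `CC(C)c1cc(N)c2cc(NC(=O)/C=C/c3ccc(C(F)(F)F)cc3)ccc2n1` gives 2.1 nM and compound 2 `CC(C)(C)c1cc(N)c2cc(NC(=O)/C=C/c3ccc(C(F)(F)F)cc3)ccc2n1` gives 0.3 nM. The step of a 1.8-fold lower number from compound 1 to compound 3 (0.24 log units; within the scatter) lies within the scatter, whereas a 4.0-fold higher number from compound 2 to compound 3 (0.60 log units; beyond the scatter) and a 7.0-fold lower number from compound 1 to compound 2 (0.85 log units; beyond the scatter) are modest steps beyond it. Compound 4 `Nc1cc(C2CCCC2)nc2ccc(NC(=O)/C=C/c3ccc(C(F)(F)F)cc3)cc12` differs from compound 3 by cyclopentyl in place of cyclohexyl on an aromatic carbon. For the measured compounds named here, the steps that bear on this are the exchanges of the same group on compound 1 and compound 2 for the group on compound 3, of which only the tert-butyl case moved the number beyond the scatter. A smaller ring is therefore expected to leave this assay about unchanged, a 1.3-fold higher number from compound 3 to compound 4 (0.10 log units; within the scatter). Compound 4 is estimated at 1.5 nM, range 0.5 nM to 4.5 nM.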

Compound 4, half-maximal inhibitory concentration: 0.8 nM
Beside the measured number, compound 4's estimate is 1.9-fold (0.27 log units) above it, and the stated range covers the measured number.
By their numbers in this assay, from the lowest: compound 2; then compounds 4, 3 and 1 (each within the scatter of the next, the first and the last beyond it).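

Exchanging cyclohexyl for cyclopentyl next to the ring nitrogen gives a 1.5-fold lower number from compound 3 to compound 4 (0.18 log units; within the scatter), so this assay does not separate these two ring sizes. Cyclopentyl does separate from both open-chain groups, with a 2.6-fold lower number from compound 1 to compound 4 (0.42 log units; beyond the scatter) and a 2.7-fold higher number from compound 2 to compound 4 (0.43 log units; beyond the scatter), whereas cyclohexyl stayed within the scatter of isopropyl. No measurement on hand accounts for these steps. Still open, going by these compounds, is whether cyclopropyl, or a ring holding an oxygen such as tetrahydropyranyl, keeps the number at this position. Also open, on these data alone, is whether an amine on the ring is tolerated there.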